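The source may report more compounds than this note shows. Statements on the series, on what has been measured and on what is new or still open speak of the compounds shown alone.

Measured so far:
compound 1, `CC(/C=N/Nc1ccc([N+](=O)[O-])cc1)=N\NC(=O)c1ccc(N)cc1` — in a functional assay on cells (Splenocyte, Mus musculus, strain BALB/c) for inhibition, read by scintillation counting and thymidine incorporation, with a stated time of 72 h (on this read-out higher numbers stand for weaker inhibition and lower numbers for stronger inhibition), compound 1 gives > 12000 nM, which is a limit of the assay and not a number.
compound 2, `CC(/C=N/Nc1ccc([N+](=O)[O-])cc1)=N\NC(=O)c1ccccc1C` — in this assay compound 2 gives 6000 nM.

Compound 1 thus stands only at a limit, recorded as the limit of > 12000 nM in this assay, at which 1 of the 2 values shown sits. Compound 3, `CC(/C=N/Nc1ccc([N+](=O)[O-])cc1)=N\NC(=O)c1ccc(C(F)(F)F)cc1`, differs from compound 1 by trifluoromethyl in place of amino on an aromatic carbon. Going by the values given here, the one measured step from compound 1, an at least 2.0-fold lower number from compound 1 to compound 2 (0.30 log units; that floor lies within the scatter), changes the same ring with a different group and offers only a floor, not a firm size. Compound 3 is therefore expected to stay near the limit, with an at least 1.3-fold lower number from compound 1 to compound 3 (0.12 log units; that floor lies within the scatter) as the estimated step. The estimate for compound 3 is 9000 nM, ranging from 3000 nM to 30000 nM, and a limit remains likely.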

Compound 3, half-maximal inhibitory concentration: > 12000 nM
Compound 3 gave a limit, no number; the forecaster's own chance of this, stated with the estimate: 50%; middle value at least 1.3-fold (0.12 log units) from the limit.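

Going by these compounds alone, compound 1 and compound 3 both stand at a limit and not at a number, so no step between them can be read: the limit of > 12000 nM in this assay, at which 2 of the 3 values shown sit. The compounds shown leave open whether trifluoromethyl in place of amino changes inhibition at all.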